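From Pyridin-2-yl to Cyclopropyl in a Toxicity Test

The compounds below may be only part of what the source reports. "The series", "measured", "known", "first", "only" and "open" are said of these compounds alone.

Compound 1 (`Cn1c([N+](=O)[O-])cnc1C(=O)NC1CC1`) reads > 100000 nM in a toxicity assay on HEK293 cells (Homo sapiens) for inhibition, read by resazurin assay, with a stated time of 24 h (a lower number here means that less compound is tolerated, a higher number that more compound is tolerated), and this is a limit of the assay, not a number. Compound 2 (`O=C(NCc1cccc(OC(F)(F)F)c1)c1ncc([N+](=O)[O-])[nH]1`) reads > 100000 nM in this assay and this too is only a limit. Compound 3 (`NC(=O)c1nc([N+](=O)[O-])cn1Cc1ccccn1`) reads > 100000 nM in this assay and this is again a limit. Compound 3 therefore stands at the limit of > 100000 nM in this assay, at which 3 of the 3 values shown sit, and cannot be ordered against the other two.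

Compound 4 (`NC(=O)c1nc([N+](=O)[O-])cn1CC1CC1`) has cyclopropyl in place of pyridin-2-yl on a saturated chain carbon bound to an aromatic nitrogen and has not yet been measured. Within the data shown here, no measured step gives a size for this change, so no step beyond the scatter is expected in this assay in either direction. The estimated step is a number no higher from compound 3 to compound 4 (the limit leaves the size open) and it is expected to be no more than scatter. For compound 4 the expected value is 100000 nM as an estimate, with an estimated range from 50000 nM to 200000 nM and a likely report as a limit again.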

Compound 4, half-maximal cytotoxic concentration: > 100000 nM
Compound 4 gave a limit, no number; the forecaster's own chance of this, stated with the estimate: 90%; the middle value sits exactly at the limit.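

Compound 3 and compound 4 both give only a limit in this assay, so no step can be read between them: the limit of > 100000 nM in this assay, at which 4 of the 4 values shown sit. The compounds shown leave open whether cyclopropyl and pyridin-2-yl differ at all in this assay, since none of them gives a number there.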